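Shortening the thioether side chain of compound 2

The source may report more compounds than this note shows. Statements on the series, on what has been measured and on what is new or still open speak of the compounds shown alone.

Compound 2 `CCC(Sc1nc2c(cnn2C)c(=O)n1-c1ccccc1)c1ccccc1` gives 119 nM in an assay on isolated protein for inhibition of Retinaldehyde dehydrogenase 3 (Homo sapiens); on this read-out higher numbers stand for weaker inhibition and lower numbers for stronger inhibition. Among the three measured compounds it holds the second-highest number; its nearest neighbour is compound 3 `CC(C)C(Sc1nc2c(cnn2C)c(=O)n1-c1ccccc1)c1ccccc1` with 130 nM, and the furthest is compound 1 `CC(Sc1nc2nn(C3(C)COC3)cc2c(=O)n1-c1ccccc1)c1ccccc1` with 50 nM. Compound 1 differs from compound 2 in more than one place, so that gap is not a single step.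

Compound 4 `C[C@@H](Sc1nc2c(cnn2C)c(=O)n1-c1ccccc1)c1ccccc1` carries 1-phenylethyl in place of 1-phenylpropyl on a sulfur. Going by the values given here, one measured step bears on the side chain on the sulfur: a 1.1-fold higher number from compound 2 to compound 3 (0.04 log units; within the scatter). Among the compounds with values here, that step lengthened the chain and left the number essentially unchanged; the present change shortens it and fixes a stereocentre, for which no measured pair exists. Compound 1 carries the same 1-phenylethyl group but alongside its other changes, so it is only a loose pointer. The expectation for compound 4 is therefore a step of a 1.5-fold lower number from compound 2 to compound 4 (0.17 log units; within the scatter), small and uncertain in direction. Compound 4 is estimated at 80 nM, with a range from 25 nM to 250 nM.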

Compound 4, half-maximal inhibitory concentration: 34 nM
The estimate for compound 4 lay 2.4-fold (0.37 log units) above the measured number, within the range that was stated.
By their numbers in this assay, from the lowest: compounds 4 and 1 (each within the scatter of the next); then compounds 2 and 3 (each within the scatter of the next).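

In this assay the side chain on the sulfur proves responsive: 1-phenylethyl in place of 1-phenylpropyl gives a 3.5-fold lower number from compound 2 to compound 4 (0.54 log units; beyond the scatter) and so moves the number beyond the scatter, whereas the added methyl on the chain gave a 1.1-fold higher number from compound 2 to compound 3 (0.04 log units; within the scatter) and no readable change. The position therefore does not tolerate every change on this chain equally. This single step joins two changes, a shorter chain and a defined stereocentre, so its size cannot be divided between them.

Open, from the compounds shown here alone, are the opposite stereocentre of 1-phenylethyl and benzyl on the same sulfur, which would help separate those two changes. No measurement at hand accounts for the step.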